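Swapping oxan-4-yl for 1-methylpiperidin-4-yl: working notes

This account rests on a few compounds, and the source may have more. Where it says the series, first, only, none or still open, it means among the compounds named here.

- Compound 1 (`Cc1cc2ncnn2cc1Nc1ncc2c(n1)n(C1CCN(C)CC1)c(=O)n2C`): 0.3
- Compound 2 (`Cc1cc2ncccc2cc1Nc1ncc2c(n1)n(C1CCOCC1)c(=O)n2C`): 2.5

In a physicochemical assay for lipophilicity, read by HPLC, using the shake flask method, measured as octanol-water partition, at pH 7.4 (on this read-out higher numbers stand for higher lipophilicity and lower numbers for lower lipophilicity), compound 2 stands highest of the two measured compounds, and compound 1 lies lower by a gap beyond the scatter. The next compound to be read is compound 3 (`Cc1cc2ncccc2cc1Nc1ncc2c(n1)n(C1CCN(C)CC1)c(=O)n2C`), which departs from compound 2 in one place. The change is 1-methylpiperidin-4-yl in place of oxan-4-yl on an aromatic nitrogen with 1-methylpiperidin-4-yl in place of oxan-4-yl on an aromatic nitrogen. For the measured compounds named here, no measured pair isolates this change, as compound 1 and compound 2 differ in more than one place. Going by the values given here, compound 1 carries the entering group and reads 0.3 in this assay and is the only guide available, though its gap to compound 2 cannot be assigned to a single change. Only part of that gap is expected to follow this group. The estimated step of a number 0.90 log units lower from compound 2 to compound 3 (beyond the scatter) is expected to be a fall beyond the scatter. The estimated value for compound 3 is 1.6 within an expected range of 1.1 to 2.1 once measured.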

Compound 3, distribution coefficient: 1.8
Estimate against measurement, compound 3: 0.20 log units below, and the stated range covers the measured number.
By their numbers in this assay, from the lowest: compound 1; then compound 3; then compound 2.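

For the compounds shown here, replacing oxan-4-yl with 1-methylpiperidin-4-yl on an aromatic nitrogen gives, in this assay, a number 0.70 log units lower from compound 2 to compound 3 (beyond the scatter), the first reading of this change on its own, with the rest of the structure held constant. Compound 3 gives 1.8 and compound 1, which carries the same 1-methylpiperidin-4-yl group, gives 0.3, so the entering group alone does not bring the reading down to that of compound 1, and the one other place where these two compounds differ also goes with a change in the number. Nothing at hand explains the size or direction of the step from oxan-4-yl to 1-methylpiperidin-4-yl.

On these data alone, a single pair defines this step, so it remains open whether the same exchange would give a similar step on the core of compound 1. Also open, as far as these compounds go, is how this assay would respond at this aromatic nitrogen to groups outside this pair of six-membered rings, such as a simple dimethylamino chain, a carboxylic acid or a longer alkyl chain.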